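From hydroxymethyl to trifluoromethyl on a shared core

A few compounds are considered here, and "the series" means these few. Any claim that something is new, unique, unknown or untested is made for them only; others in the source may bear on it.

Among the compounds with values here, only two compounds have so far been measured in a physicochemical assay for lipophilicity, read by HPLC, at pH 7.5; a higher number here means a more lipophilic compound, a lower number a more polar compound. Within the data shown here, compound 1 `CC[C@@H](Nc1c(C#N)c(-c2ccc(-c3ccccc3N(C)C)cc2)nc2cnccc12)C(N)=O` gives 3.2, and compound 2 `CC[C@@H](Nc1c(C#N)c(-c2ccc(-c3ccccc3CO)cc2)nc2cnccc12)C(N)=O` gives 2.1, the lower of the two numbers and clearly apart from its only neighbour. Among the measured compounds shown here, the single measured step is a number 1.10 log units lower from compound 1 to compound 2 (beyond the scatter), a large change beyond the scatter, with hydroxymethyl in place of dimethylamino on an aromatic carbon.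

The next compound, compound 3 `CC[C@@H](Nc1c(C#N)c(-c2ccc(-c3ccccc3C(F)(F)F)cc2)nc2cnccc12)C(N)=O`, keeps the shared core and changes that hydroxymethyl group: trifluoromethyl in place of hydroxymethyl on an aromatic carbon. In words, trifluoromethyl stands in place of hydroxymethyl on an aromatic carbon, ortho to a large group.

For the measured compounds named here, no measured compound carries trifluoromethyl, so the evidence is indirect. Going by the values given here, still, the one step that bears on this change, a number 1.10 log units lower from compound 1 to compound 2 (beyond the scatter), shows that leaving hydroxymethyl for another group can move this assay by a large amount. A change of similar size in the opposite direction is therefore expected. The expected step is a number 1.20 log units higher from compound 2 to compound 3 (beyond the scatter), upward and beyond the scatter. For compound 3 the estimate is 3.3, with an expected range of 2.8 to 3.9.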

Compound 3, distribution coefficient: 3.1
Estimate against measurement, compound 3: 0.20 log units above; the measured number falls inside the stated range.
By their numbers in this assay, from the lowest: compound 2; then compounds 3 and 1 (each within the scatter of the next).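

On an aromatic carbon of the six-membered ring, ortho to a large group, this assay now reads a second replacement of hydroxymethyl, with a number 1.00 log units higher from compound 2 to compound 3 (beyond the scatter) for trifluoromethyl, so the earlier drop on moving from dimethylamino to hydroxymethyl no longer stands alone. The new compound also allows a comparison the earlier pair could not give, between two groups that both differ from hydroxymethyl: a number 0.10 log units lower from compound 1 to compound 3 (within the scatter) for trifluoromethyl in place of dimethylamino, which leaves compound 1 and compound 3 together and compound 2, with hydroxymethyl, apart from both by steps beyond the scatter. No measurement shown here explains why hydroxymethyl stands apart from the other two groups.

The compounds shown leave open how a carboxylic acid, a primary amine or a longer chain such as hydroxyethyl would read at this position, and whether any of them would fall with hydroxymethyl or with the other two groups. They also leave open whether these same replacements would give steps of similar size on another aromatic carbon of this ring or on a different core.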